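Moving the Ring Nitrogen: From Compound 3 to Compound 4

A few compounds are considered here, and "the series" means these few. Any claim that something is new, unique, unknown or untested is made for them only; others in the source may bear on it.

Of the compounds shown here, three that share one core have been measured in a functional assay on A-375 cells (Homo sapiens) for antiproliferative activity, read by CCK-8 assay, with a stated time of 72 h, tested at 2 uM; a higher number here means a stronger effect of the compound at the concentration tested, a lower number a weaker effect. Compound 1 `Nc1ccccc1NC(=O)c1ccc(CSC(=S)N2CCN(C3CCCCC3)CC2)cc1` gives 31.7%, compound 2 `Nc1ccccc1NC(=O)c1ccc(CSC(=S)N2CCN(Cc3ccncc3)CC2)cc1` gives 33.1%, and compound 3 `Nc1ccccc1NC(=O)c1ccc(CSC(=S)N2CCN(c3ccncc3)CC2)cc1` gives 85.7%, the highest of the three. The step of a number 54 percentage points higher from compound 1 to compound 3 (beyond the scatter) and the step of a number 52.6 percentage points higher from compound 2 to compound 3 (beyond the scatter) show that a pyridin-4-yl bound directly to the amine nitrogen in the ring sets compound 3 apart, whereas the step of a number 1.4 percentage points higher from compound 1 to compound 2 (within the scatter) stays within the scatter. Compound 4 `Nc1ccccc1NC(=O)c1ccc(CSC(=S)N2CCN(c3cccnc3)CC2)cc1` holds the same atoms, joined differently: pyridin-3-yl in place of pyridin-4-yl on an amine nitrogen in a ring. Going by the values given here, none of the measured steps moves the nitrogen within this aromatic ring, so they establish only that a directly attached pyridine ring matters, not which of its atoms carries the nitrogen. A moderate drop in this assay is therefore expected, with wide uncertainty, as a step of a number 20.7 percentage points lower from compound 3 to compound 4 (beyond the scatter). Compound 4 is estimated at 65%, within a range from 35% to 90%.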

Compound 4, a percentage reported as inhibition, at one concentration (the size of the read-out at that concentration, not a potency): 40.5%
Compound 4: the middle estimate sits 24.5 percentage points above what was measured; the measured number falls inside the stated range.
By their numbers in this assay, from the lowest: compounds 1, 2 and 4 (each within the scatter of the next); then compound 3.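

In this assay, where the nitrogen sits within the pyridine ring counts for as much as the ring being directly attached: with the same atoms, pyridin-3-yl in place of pyridin-4-yl gives a large fall (a number 45.2 percentage points lower from compound 3 to compound 4 (beyond the scatter)). What set compound 3 apart does not carry over to compound 4, whose steps from the other two compounds stay small (a number 7.4 percentage points higher from compound 2 to compound 4 (within the scatter); a number 8.8 percentage points higher from compound 1 to compound 4 (within the scatter)). A pyridine ring bound directly to the amine nitrogen in the ring is therefore not enough on its own, and among these compounds only pyridin-4-yl in that place gives the high number.

From the compounds shown here alone, how a pyridin-2-yl or a plain phenyl ring on the same nitrogen would read remains open. Why the place of the ring nitrogen counts so much also stays open, and no measurement here speaks to the reason.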